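Removing the Silyl Ether and the Benzyl Ester

The compounds below may be only part of what the source reports. "The series", "measured", "known", "first", "only" and "open" are said of these compounds alone.

Measured compounds:
compound 1 `CC(C)(C)[Si](C)(C)O[C@@H]1CCCO[C@@H]1/C=C/C(=O)OCc1ccccc1`: 37000 nM
compound 2 `O=C(/C=C/[C@H]1OCCC[C@H]1O)OCc1ccccc1`: > 100000 nM
compound 3 `COC(=O)/C=C/[C@H]1OCCC[C@H]1O[Si](C)(C)C(C)(C)C`: > 100000 nM

In a functional assay on SW1573 cells (Homo sapiens) for antiproliferative activity, read by sulforhodamine B assay, with a stated time of 48 h (a higher number here means a weaker inhibitor of growth, a lower number a stronger inhibitor of growth), compound 1 gives 37000 nM. Compound 2 reaches only the limit of this assay, giving > 100000 nM. Compound 3 likewise reaches only that limit in this assay, giving > 100000 nM. The change from compound 1 to compound 2 is a hydrogen atom in place of a group of 7 heavy atoms (6 carbon, 1 silicon; no ring), on an oxygen on a saturated carbon, and it produced an at least 2.7-fold higher number from compound 1 to compound 2 (0.43 log units; beyond the scatter). The change from compound 1 to compound 3 is hydrogen in place of phenyl on a saturated chain carbon bound to an oxygen next to a carbonyl group, and it produced an at least 2.7-fold higher number from compound 1 to compound 3 (0.43 log units; beyond the scatter). Both steps are bounded by the limit of > 100000 nM in this assay, at which 2 of the 3 values shown sit, so their true size is open.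

Compound 4 `COC(=O)/C=C/[C@H]1OCCC[C@H]1O` is not yet measured. It differs from compound 2 as hydrogen in place of phenyl on a saturated chain carbon bound to an oxygen next to a carbonyl group. This is the same change as the one from compound 1 to compound 3, made at the same place, and it occurs twice among these compounds. The cores of compound 2 and compound 1 differ as a hydrogen atom in place of a group of 7 heavy atoms (6 carbon, 1 silicon; no ring), on an oxygen on a saturated carbon.

Beside an at least 2.7-fold higher number from compound 1 to compound 3 (0.43 log units; beyond the scatter), the step expected in this assay is a step that the limit leaves unreadable from compound 2 to compound 4, resting on compound 1 giving 37000 nM while the same change there gave an at least 2.7-fold higher number from compound 1 to compound 3 (0.43 log units; beyond the scatter). Since compound 2 already sits at the limit, compound 4 is expected to give about 300000 nM, with a range from 100000 nM to 1000000 nM, and most likely to be reported only as a limit again.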

Compound 4, concentration for 50% growth inhibition: > 100000 nM
Compound 4 gave a limit, no number (the forecaster's own chance of this, stated with the estimate: 90%); the middle value does not contradict the limit.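

In this assay no step can be read from compound 2 to compound 4, because both compounds stand at a limit and neither gives a number: the limit of > 100000 nM in this assay, at which 3 of the 4 values shown sit. The compounds shown leave open how far compound 2, compound 3 and compound 4 lie past that limit, and so what size the change from phenyl to hydrogen has in compound 2.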